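Swapping the oxadiazolone ring on the benzyl group of compound 2

This account rests on a few compounds, and the source may have more. Where it says the series, first, only, none or still open, it means among the compounds named here.

Measured so far:
compound 1 `Cn1nc2c(=O)n(CC3(O)CCN(Cc4ccc(-c5ccco5)cc4Cl)CC3)cnc2c1-c1ccc(CNS(C)(=O)=O)cc1`: 65.3 nM
compound 2 `Cn1nc2c(=O)n(CC3(O)CCN(Cc4ccc(-c5n[nH]c(=O)o5)cc4Cl)CC3)cnc2c1-c1ccc(CN)cc1`: 171 nM
compound 3 `CC(C)NCc1ccc(-c2c3ncn(CC4(O)CCN(Cc5ccc(-c6ccco6)cc5Cl)CC4)c(=O)c3nn2C)cc1`: 29.1 nM

In an assay on isolated protein for inhibition of ubiquitin carboxyl-terminal hydrolase 7 (Homo sapiens), with stated times of 30 min and 2 h (on this read-out higher numbers stand for weaker inhibition and lower numbers for stronger inhibition), compound 2 gives the highest of the three numbers; compound 1 sits closest to it, and compound 3 lies furthest away. Compound 4 `Cn1nc2c(=O)n(CC3(O)CCN(Cc4ccc(-c5ccsc5Cl)cc4Cl)CC3)cnc2c1-c1ccc(CN)cc1` keeps everything in compound 2 except one group: a group of 6 heavy atoms (4 carbon, 1 sulfur, 1 chlorine; one five-membered aromatic ring with 1 hetero atom) in place of a group of 6 heavy atoms (2 carbon, 2 nitrogen, 2 oxygen; one five-membered aromatic ring with 3 hetero atoms), on an aromatic carbon.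

Within the data shown here, the only step measured on a single change is a 2.2-fold lower number from compound 1 to compound 3 (0.35 log units; beyond the scatter), which concerns the amine nitrogen at the other end of the molecule and says nothing about the aromatic carbon altered here. Among the measured compounds shown here, compound 1 and compound 2 differ in two places at once, so no step between them can be drawn; what the two values show is that compound 2, with the oxadiazolone, gives 171 nM, while compound 1 gives 65.3 nM. The effect of the entering 2-chlorothiophen-3-yl ring therefore has no direct precedent among these compounds.

On this basis compound 4 is expected to land near the lower end of the measured range, with a step of about a 2.4-fold lower number from compound 2 to compound 4 (0.39 log units; beyond the scatter), and its estimated value is 70 nM, within a range from 25 nM to 200 nM.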

Compound 4, half-maximal inhibitory concentration: 453 nM
Beside the measured number, compound 4's estimate is 6.5-fold (0.81 log units) below it; measured number outside the range, above it.
By their numbers in this assay, from the lowest: compound 3; then compound 1; then compound 2; then compound 4.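

In this assay, the exchange of the oxadiazolone for the 2-chlorothiophen-3-yl ring gives a 2.6-fold higher number from compound 2 to compound 4 (0.42 log units; beyond the scatter), the first step read at this aromatic carbon, which stands para to a large group and meta to a chloro group. It shows that the number responds to the group held at this carbon even when the count of 6 heavy atoms stays the same and the five-membered aromatic ring is kept, so that ring size and heavy-atom count alone do not settle the outcome. What changes along with the number is the make-up of the ring: 1 hydrogen-bond donor and 3 hydrogen-bond acceptors leave, 0 hydrogen-bond donors and 1 hydrogen-bond acceptor enter, and sulfur and chlorine replace nitrogen and oxygen, yet no measurement here ties the higher number to any one of these differences.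

Going by these compounds, whether the rise belongs to the thiophene ring or to its chlorine stays open, and a plain thiophen-3-yl or a phenyl ring at this carbon would be needed to separate the two. Steps from compound 4 to compound 1 or compound 3 cannot be read, as those pairs differ in more than one place, so how the ring carried at this carbon by compound 1 and compound 3 would compare on the amine of compound 2 also stays open.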